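A chain-end ester on a long-chain isoflavone ether

A few compounds are considered here, and "the series" means these few. Any claim that something is new, unique, unknown or untested is made for them only; others in the source may bear on it.

Compound 2 `O=c1c(-c2ccc(O)cc2)coc2cc(OCCCCCCO)ccc12` carries a 6-hydroxyhexyl group on an oxygen on an aromatic ring of the shared core. In an assay (Cricetulus griseus) for inhibition of Monoamine oxidase (Homo sapiens) (on this read-out higher numbers stand for weaker inhibition and lower numbers for stronger inhibition), compound 2 gives > 9000 nM, which is a limit of the assay and not a number. Compound 1 `CCCCC(Oc1ccc2c(=O)c(-c3ccc(O)cc3)coc2c1)C(=O)OCC` also sits at a limit in this assay, with >> 9000 nM. Compound 3 `CC(C)Oc1ccc2c(=O)c(-c3ccc(O)cc3)coc2c1` gives 200 nM in this assay, and the change is an at least 45-fold lower number from compound 2 to compound 3 (1.65 log units; beyond the scatter). Compound 4 `CCOC(=O)CCCCCOc1ccc2c(=O)c(-c3ccc(O)cc3)coc2c1` differs from compound 2 by ethoxycarbonyl in place of hydroxymethyl on a saturated chain carbon, five bonds along the chain from an oxygen on an aromatic ring. Among the measured compounds shown here, no measured step alters only the end of the chain; the one large step measured, from compound 2 to compound 3, replaces the whole chain. Compound 4 is therefore expected to remain near the limit, with a step that the limit leaves unreadable from compound 2 to compound 4 expected to be no larger than the scatter. The estimate for compound 4 is 15000 nM, with a range from 5000 nM to 50000 nM.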

Compound 4, half-maximal inhibitory concentration: 5300 nM
The estimate for compound 4 lay 2.8-fold (0.45 log units) above the measured number; the measured number falls inside the stated range.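

In this assay compound 4 returns a number and not a limit, so a long chain on this oxygen does not by itself hold the read-out at the limit. Ethoxycarbonyl in place of hydroxymethyl gives an at least 1.6-fold lower number from compound 2 to compound 4 (0.22 log units; that floor lies within the scatter) at the end of the chain. Going by these compounds, only this floor can be read, and the true size of the step stays unknown, because compound 2 stands at a limit: the limit of > 9000 nM in this assay, at which 1 of the 4 values shown sits.

On these data alone, whether a carboxylic acid or an amine at the same chain end would read differently remains open. So does the reading of ethoxycarbonyl on a shorter or longer chain.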